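The source may hold more compounds than are shown below. What is called first, only, known or untested is meant among the compounds shown, and "the series" means these compounds.

Compound 2 `COc1ccc2c(c1)c(CC(=O)NS(=O)(=O)c1ccc(N3CCN(C)CC3)c([N+](=O)[O-])c1)c(C)n2-c1ccc(C)cc1` stands only at a limit in an assay on isolated protein for binding affinity to Apoptosis regulator Bcl-2 (Homo sapiens), read by fluorescence polarization, with stated times of 30 min and 20 min (a higher number here means a weaker inhibitor, a lower number a stronger inhibitor), where compound 2 gives > 10000 nM. Compound 1 `COc1ccc2c(c1)c(CC(=O)NS(=O)(=O)c1ccc(Cl)c([N+](=O)[O-])c1)c(C)n2-c1ccc(C)cc1` is likewise a limit: in this assay compound 1 gives > 10000 nM. The step that the two limits leave unreadable from compound 1 to compound 2 cannot be read, since the limit of > 10000 nM in this assay, at which 2 of the 2 values shown sit, holds both values. Compound 3 `COc1ccc2c(c1)c(CC(=O)NS(=O)(=O)c1ccc(NCc3ccccc3)c([N+](=O)[O-])c1)c(C)n2-c1ccc(C)cc1` differs from compound 2 by benzylamino in place of 4-methylpiperazin-1-yl on an aromatic carbon. With no readable measured step, no change beyond the scatter is expected in this assay, and compound 3 is expected to stay at the limit. Compound 3 is estimated at 15000 nM, between 3000 nM and 60000 nM, an expected step that the limit leaves unreadable from compound 2 to compound 3.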

Compound 3, inhibition constant: > 10000 nM
Compound 3: no number, only a limit (the forecaster's own chance of this, stated with the estimate: 70%); the middle value does not contradict the limit.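

No step between compound 1, compound 2 and compound 3 can be read, because each result is a limit and not a number: the limit of > 10000 nM in this assay, at which 3 of the 3 values shown sit.

From the compounds shown here alone, whether these three compounds differ in binding in this assay remains open.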